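The source may report more compounds than this note shows. Statements on the series, on what has been measured and on what is new or still open speak of the compounds shown alone.

Compound 1 `CCCCNc1nc(N)nc2cccc(OC)c12` | > 25000 nM | a limit
Compound 2 `CCCCNc1nc(N)nc2cccc(OCc3cccnc3)c12` | > 25000 nM | a limit

In an ADME assay on HEK293 cells (Homo sapiens) for cytotoxicity, with a stated time of 6 h (a higher number here means that more compound is tolerated, a lower number that less compound is tolerated), compound 2 gives > 25000 nM as a limit of the assay, not a number. Compound 1 gives > 25000 nM as a limit too. Compound 3 `CCCCNc1nc(N)nc2cccc(C(=O)N(C)C(C)C)c12` is the next structure, and isopropyl(methyl)carbamoyl in place of (pyridin-3-yl)methoxy on an aromatic carbon is its change from compound 2, isopropyl(methyl)carbamoyl in place of (pyridin-3-yl)methoxy on an aromatic carbon. Within the data shown here, the one measured step that the two limits leave unreadable from compound 1 to compound 2 has no readable size, so it offers no size to carry over. What remains is the limit of > 25000 nM in this assay, at which 2 of the 2 values shown sit, and so no step beyond the scatter is expected in this assay in either direction. The estimated step is a step that the limit leaves unreadable from compound 2 to compound 3 in size. For compound 3 the expected value is 30000 nM with an estimated range from 12000 nM to 60000 nM and another limit is likely.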

Compound 3, half-maximal cytotoxic concentration: > 25000 nM
Compound 3 gave a limit, no number (the forecaster's own chance of this, stated with the estimate: 80%); the middle value lies beyond the limit too.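

Among these compounds, compound 1, compound 2 and compound 3 all give limits, not numbers, in this assay, and no step between them can be read. The compounds shown leave open whether changing the group on this aromatic carbon alters cytotoxicity at all.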